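The source may hold more compounds than are shown below. What is called first, only, known or untested is meant among the compounds shown, and "the series" means these compounds.

Measured compounds:
Compound 1, `O=C(Nc1ccccc1Br)N1CCN(c2ccnc(Cl)n2)CC1` — in an assay on isolated protein for antagonist activity at transient receptor potential cation channel subfamily V member 1 (Homo sapiens) (a higher number here means a weaker inhibitor, a lower number a stronger inhibitor), compound 1 gives 1070 nM.
Compound 2, `O=C(Nc1cccc(C(F)(F)F)c1)N1CCN(c2ccnc(Cl)n2)CC1` — in this assay compound 2 gives 543 nM.

Compound 1 carries the highest of the two numbers shown, but its only neighbour, compound 2, sits within the usual scatter of it, so the two cannot be ranked against each other. Both share the same core; they differ only in the group on the phenyl ring of the urea.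

The next compound, compound 3, `O=C(Nc1ccccc1[N+](=O)[O-])N1CCN(c2ccnc(Cl)n2)CC1`, takes compound 1 as its starting point and makes one change: nitro in place of bromo on an aromatic carbon, a nitro in place of bromo on an aromatic carbon, ortho to a large group. Among the compounds with values here, no measured pair in this set shows the effect of such a swap, so there is no step in this assay to lean on. With nothing of that kind to go on, the expectation for a 1.4-fold higher number from compound 1 to compound 3 (0.15 log units; within the scatter) is a small step, if any, toward a higher number, most likely not beyond the scatter. On that basis, compound 3 is estimated at 1500 nM in this assay, with a range from 500 nM to 5000 nM.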

Compound 3, half-maximal inhibitory concentration: 854 nM
Compound 3: the middle estimate sits 1.8-fold (0.24 log units) above what was measured, within the range that was stated.
By their numbers in this assay, from the lowest: compounds 2, 3 and 1 (each within the scatter of the next).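

In this assay, the first step measured on this aromatic carbon, ortho to a large group, is a 1.3-fold lower number from compound 1 to compound 3 (0.10 log units; within the scatter). Nitro brings 3 heavy atoms and 2 hydrogen-bond acceptors where bromo had a single bromine and none, yet the two values cannot be told apart, so in this one pair that difference in make-up leaves no reading beyond the scatter. Nothing measured independently of these values bears on how the two groups act at this place, so the pair can be reported only as a matched comparison, with no explanation attached.

With only bromo and nitro compared at this carbon, the compounds shown leave open whether an amine, a carboxylic acid, a methoxy group or a bare hydrogen there would give a value beyond the scatter of compound 1. They also leave open whether the same swap would read alike on another carbon of the phenyl ring or on a different group in place of the chlorine of the shared core.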